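Fluoro in Place of Hydroxy: From Compound 2 to Compound 3

A few compounds are considered here, and "the series" means these few. Any claim that something is new, unique, unknown or untested is made for them only; others in the source may bear on it.

Compound 1, `CC(=O)OCCc1c(C)nc(Cl)nc1Cl`: > 100000 nM in a functional assay on MCF7 cells (Homo sapiens) for antiproliferative activity, read by MTT assay, with a stated time of 24 h (a lower number here means a stronger inhibitor, a higher number a weaker inhibitor), a limit.
Compound 2, `COc1nc(Cl)nc(C)c1CCO`: > 100000 nM in this assay, a limit.

Compound 1 gives only a limit in this assay. Compound 2 likewise gives only a limit in this assay. Compound 2 therefore stands at the limit of > 100000 nM in this assay, at which 2 of the 2 values shown sit, and no number separates it from compound 1. Compound 3, `COc1nc(Cl)nc(C)c1CCF`, differs from compound 2 in one place: fluoro in place of hydroxy on a saturated chain carbon, two bonds along the chain from an aromatic carbon. Among the compounds with values here, no measured step connects compound 2 with another compound, so the size of this change in this assay cannot be read from the data, and nothing in the measured values points to a move beyond the scatter. Compound 3 is expected to remain at the limit, with an expected step that the limit leaves unreadable from compound 2 to compound 3. The estimated value for compound 3 is 150000 nM, ranging from 50000 nM to 500000 nM.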

Compound 3, half-maximal inhibitory concentration: > 100000 nM
Compound 3 gave a limit, no number (the forecaster's own chance of this, stated with the estimate: 85%); the middle value does not contradict the limit.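

Compound 3, like compound 2, gives only a limit in this assay, so no step can be read between them: the limit of > 100000 nM in this assay, at which 3 of the 3 values shown sit.

The compounds shown leave open whether fluoro in place of hydroxy changes antiproliferative activity at all.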